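The source may report more compounds than this note shows. Statements on the series, on what has been measured and on what is new or still open speak of the compounds shown alone.

In a functional assay on B16 cells (Mus musculus) for inhibition (on this read-out higher numbers stand for weaker inhibition and lower numbers for stronger inhibition), compound 1 `CC(C)CN(NC(=O)OCc1ccccc1)C(=O)CN(Cc1ccccc1)NC(=O)CBr` gives 1800 nM. Compound 2 `O=C(CN(Cc1ccccc1)NC(=O)CBr)NNC(=O)OCc1ccccc1` gives 1500 nM, and compound 3 `CC(C)CN(CC(=O)NN(Cc1ccccc1)c1cnccn1)NC(=O)Cc1cccc(Br)c1` gives 33300 nM. Compound 1 therefore sits level with compound 2, at the low end of these three numbers, and well below compound 3.

Compound 4 `CC(C)CN(NC(=O)OCc1ccccc1)C(=O)CN(Cc1ccccc1)/N=C/c1ccccc1B(O)O` comes from compound 1 through one structural change: a group of 11 heavy atoms (7 carbon, 1 boron, 1 nitrogen, 2 oxygen; one six-membered aromatic ring of carbon only) in place of a group of 5 heavy atoms (2 carbon, 1 nitrogen, 1 oxygen, 1 bromine; no ring), on an amine nitrogen. The group that leaves is ((bromomethyl)carbonyl)amino.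

For the measured compounds named here, the only measured single-place step, a 1.2-fold lower number from compound 1 to compound 2 (0.08 log units; within the scatter), puts hydrogen in place of isobutyl on an amide-type nitrogen. It leaves the ((bromomethyl)carbonyl)amino group in place, so it gives no direct guide to this change. Among the measured compounds, only compound 3 lacks that group, and its 33300 nM hints at a higher number without it. This is weak evidence, since compound 3 also differs from compound 1 in other places.

A move towards weaker inhibition is expected, with much uncertainty: a 3.3-fold higher number from compound 1 to compound 4 (0.52 log units; beyond the scatter). The estimate for compound 4 is 6000 nM, with an expected range from 1200 nM to 30000 nM.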

Compound 4, half-maximal inhibitory concentration: 45100 nM
Estimate against measurement, compound 4: 7.5-fold (0.88 log units) below, outside the stated range (above it).
By their numbers in this assay, from the lowest: compounds 2 and 1 (each within the scatter of the next); then compounds 3 and 4 (each within the scatter of the next).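

In this assay, the group of 11 heavy atoms with its six-membered aromatic ring, put in place of ((bromomethyl)carbonyl)amino on the amine nitrogen, gives a 25-fold higher number from compound 1 to compound 4 (1.40 log units; beyond the scatter). For the compounds shown here, this is the first direct reading at this position, and it shows a large move towards weaker inhibition, whereas the earlier single-place step changed only the amide-type nitrogen and left this group untouched. Nothing measured here explains why the change costs so much.

On these data alone, the whole group changed in one step, so it remains open whether the loss follows from removing the bromine, the carbonyl or both. A plain amino group or an acetylamino group at this place could separate these, and the same replacement on compound 2 would show whether the step holds without the isobutyl group.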